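The source may hold more compounds than are shown below. What is called first, only, known or untested is meant among the compounds shown, and "the series" means these compounds.

Measured compounds:
compound 1 `COc1cc(OC)c(OC)cc1/C=C/C(=O)c1ccc(C)cc1` — 2.18 ug/mL
compound 2 `COc1cc(OC)c(-c2cc(=O)c3cc(O)ccc3o2)cc1OC` — 2.14 ug/mL
compound 3 `COc1cc(OC)c(-c2cc(=O)c3ccc(O)cc3o2)cc1OC` — 2.27 ug/mL

In a functional assay, read by Griess assay, with a stated time of 2.5 h (on this read-out higher numbers stand for weaker inhibition and lower numbers for stronger inhibition), compound 1 gives 2.18 ug/mL. Within the data shown here, on the three numbers known, compound 1 stands second highest, but the nearest value, that of compound 2 at 2.14 ug/mL, and the furthest, that of compound 3 at 2.27 ug/mL, both lie within the scatter of compound 1, so the three compounds cannot be set in any order of potency. Among the measured compounds shown here, compounds 2 and 3 are built on a different core from compound 1, and no single-point step between any two measured compounds is available; of those pairs only the values themselves can be compared, and they show no separation.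

Compound 4 `COc1cc(OC)c(OC)cc1/C=C/C(=O)c1ccc(F)cc1` remains to be measured in this assay. Against compound 1 the change is fluoro in place of methyl on an aromatic carbon. The rest of compound 1 is kept. For the measured compounds named here, nothing among the measured compounds tests this change, so the expectation rests on the compact size of the exchange alone, and a step of no more than the scatter, in either direction, is expected. Compound 4 is thus estimated to give 2.3 ug/mL in this assay, with a range from 1.1 ug/mL to 4.8 ug/mL. The step that this estimate means, a 1.1-fold higher number from compound 1 to compound 4 (0.02 log units; within the scatter), is expected to stay within the scatter.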

Compound 4, half-maximal inhibitory concentration: 1.96 ug/mL
Compound 4: middle estimate off by 1.2-fold (0.07 log units), on the high side; measured number inside the range.
By their numbers in this assay, from the lowest: compounds 4, 2, 1 and 3 (each within the scatter of the next).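

In this assay, among these compounds, the exchange of 4-methylphenyl for 4-fluorophenyl provides the only single-point step so far, and it reads a 1.1-fold lower number from compound 1 to compound 4 (0.05 log units; within the scatter). On an aromatic carbon para to a large group, methyl and fluoro therefore cannot be told apart on this read-out, and this one exchange on the core of compound 1 sets neither group ahead of the other. No measurement on hand bears on why the two groups read alike.

Methyl and fluoro are both single-atom exchanges, so it remains open whether a bulkier or chemically different group at this place, such as an amine, a carboxylic acid or a longer chain like butyl, would move the number beyond the scatter. Also open is whether any change to the methoxy groups or to the chain carrying the carbonyl in compound 1 would separate from the scatter, as the single step shown covers only this one place.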